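Halogen pattern on the sulfonamide aryl ring

This account rests on a few compounds, and the source may have more. Where it says the series, first, only, none or still open, it means among the compounds named here.

Measured compounds:
compound 1 `COc1ccc(S(=O)(=O)Nc2cc(Cl)cc(Cl)c2Br)cc1N1CCNCC1`: 3.16 nM
compound 2 `COc1ccc(S(=O)(=O)Nc2cc(Br)cc(Cl)c2Br)cc1N1CCNCC1`: 3.98 nM

Compound 2 gives the highest of the two numbers in an assay on isolated protein for binding affinity to 5-hydroxytryptamine receptor 6 (Homo sapiens); on this read-out lower numbers stand for stronger inhibition and higher numbers for weaker inhibition; its nearest neighbour is compound 1, separated by a 1.3-fold higher number from compound 1 to compound 2 (0.10 log units; within the scatter), within the scatter. Compound 3 `COc1ccc(S(=O)(=O)Nc2cc(Br)cc(Br)c2F)cc1N1CCNCC1` carries 3,5-dibromo-2-fluorophenyl in place of 2,5-dibromo-3-chlorophenyl on a sulfonamide nitrogen. Within the data shown here, the only measured step, a 1.3-fold higher number from compound 1 to compound 2 (0.10 log units; within the scatter), exchanged one halogen for another and moved nothing beyond the scatter. Among the measured compounds shown here, compound 3 instead rearranges the whole halogen pattern, for which no measured step exists, so a modest weakening is expected, a 1.6-fold higher number from compound 2 to compound 3 (0.20 log units; within the scatter). Compound 3 is estimated at 6.3 nM, within 2.5 nM to 16 nM.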

Compound 3, inhibition constant: 2.51 nM
For compound 3 the middle estimate is 2.5-fold (0.40 log units) above the measured one; low and high end bracket the measured number.
By their numbers in this assay, from the lowest: compounds 3, 1 and 2 (each within the scatter of the next).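

In this assay, the change on the sulfonamide nitrogen goes beyond a single halogen exchange: 3,5-dibromo-2-fluorophenyl replaces 2,5-dibromo-3-chlorophenyl, yet the result is a 1.6-fold lower number from compound 2 to compound 3 (0.20 log units; within the scatter). Against 2-bromo-3,5-dichlorophenyl the result is a 1.3-fold lower number from compound 1 to compound 3 (0.10 log units; within the scatter), so all three halogen patterns, including the one carrying fluorine, give values within the scatter of one another. No outside data bear on this result.

Open, as far as these compounds go, is whether halogen is needed at this position at all, as an unsubstituted phenyl, or a phenyl bearing methyl or nitrile, would show.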